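The source may report more compounds than this note shows. Statements on the series, on what has been measured and on what is new or still open speak of the compounds shown alone.

Going by the values given here, compound 2 `CC(C)c1cccc(C(C)C)c1NC(=O)NCC1(c2ccccc2C(F)(F)F)CCCC1` gives 18 nM in an assay on microsomes for inhibition of acyl-CoA:cholesterol acyltransferase (Oryctolagus cuniculus) (a lower number here means a stronger inhibitor, a higher number a weaker inhibitor), the lower of the two numbers measured so far; its nearest neighbour is compound 1 `CC(C)c1ccc(C2(CNC(=O)Nc3c(C(C)C)cccc3C(C)C)CCCC2)cc1`, which in this assay gives 48 nM. Compound 3 `COC(=O)c1ccc(C2(CNC(=O)Nc3c(C(C)C)cccc3C(C)C)CCCC2)cc1` differs from compound 2 at a single place: 4-(methoxycarbonyl)phenyl in place of 2-(trifluoromethyl)phenyl on a saturated ring carbon. Among the compounds with values here, the only measured step that bears on this change is a 2.7-fold lower number from compound 1 to compound 2 (0.43 log units; beyond the scatter), which moved the same position and brought the 2-(trifluoromethyl)phenyl group in. Compound 3 now gives that group up again, so the expectation is that the number moves back toward compound 1, a modest step upward rather than none, though a single comparison is a thin basis. Compound 3 is therefore estimated at 50 nM in this assay, with a plausible range from 20 nM to 130 nM. The expected step from compound 2 to compound 3 is a 2.8-fold higher number from compound 2 to compound 3 (0.44 log units; beyond the scatter).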

Compound 3, half-maximal inhibitory concentration: 360 nM
Beside the measured number, compound 3's estimate is 7.2-fold (0.86 log units) below it; the whole stated range lies below it.
By their numbers in this assay, from the lowest: compound 2; then compound 1; then compound 3.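

In this assay, going by these compounds alone, the earlier compounds showed only a modest effect at this position, but this change gives a 20-fold higher number from compound 2 to compound 3 (1.30 log units; beyond the scatter), so the group on the saturated ring carbon can matter far more than that first step suggested. Losing the 2-(trifluoromethyl)phenyl group is not the whole story, since compound 3 does not return to the level of compound 1: methoxycarbonyl in place of isopropyl on an aromatic carbon gives a 7.5-fold higher number from compound 1 to compound 3 (0.88 log units; beyond the scatter), which makes this the weakest of the three compounds. Nothing measured here gives a reason for either rise.

Going by these compounds, it remains open whether the methoxycarbonyl group is a special case or whether a carboxylic acid or an amide in its place would give a similar number. A plain phenyl group at this position would show how much any of these groups adds or costs.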